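The source may hold more compounds than are shown below. What is called first, only, known or untested is meant among the compounds shown, and "the series" means these compounds.

Compound 2 `CCC[C@@H](O)C1=C(Br)C(=C(Br)Br)OC1=O` and compound 1 `CCC[C@@H](OC(C)=O)C1=C(Br)C(=C(Br)Br)OC1=O` share one core and differ only in acetyl in place of hydrogen on an oxygen on a saturated carbon. In a functional assay on KB cells (Homo sapiens) for cytotoxicity (a higher number here means that more compound is needed for the effect, a lower number that less compound is needed), compound 2 gives 0.5 ug/mL, while compound 1 gives 0.3 ug/mL, a step of a 1.7-fold lower number from compound 2 to compound 1 (0.22 log units; within the scatter). Compound 3 `CCC[C@@H](O)C1=C(Br)/C(=C/I)OC1=O` is built on a different core; how that core differs from the core of compound 2 is not broken down here. In this assay compound 3 gives 0.4 ug/mL. Compound 4 `CCC[C@@H](OC(C)=O)C1=C(Br)/C(=C/I)OC1=O` stands to compound 3 as compound 1 stands to compound 2: the change is acetyl in place of hydrogen on an oxygen on a saturated carbon, at a place described in exactly the same words. Because the earlier step of a 1.7-fold lower number from compound 2 to compound 1 (0.22 log units; within the scatter) stayed within the scatter, a step of similar size is expected, namely a 1.3-fold lower number from compound 3 to compound 4 (0.12 log units; within the scatter). The value of compound 4 in this assay is therefore estimated at 0.3 ug/mL, expected to fall between 0.15 ug/mL and 0.6 ug/mL.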

Compound 4, concentration for half-maximal effect: 0.1 ug/mL
Compound 4: the middle estimate sits 3.0-fold (0.48 log units) above what was measured, and the stated range ends above it.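

In this assay, acetyl in place of hydrogen on the oxygen gives a 4.0-fold lower number from compound 3 to compound 4 (0.60 log units; beyond the scatter). Among these compounds, this step lies beyond the scatter and the earlier step on the other core does not, yet the gap between the two is no larger than such steps can differ by chance: the same change on two cores in this assay, a 1.7-fold lower number (0.22 log units; within the scatter) from compound 2 to compound 1 and a 4.0-fold lower number (0.60 log units; beyond the scatter) from compound 3 to compound 4, 2.4-fold (0.38 log units) apart, within the scatter of two such steps. As far as these two pairs can tell, the change carries over from one core to the other, but two pairs cannot fix the size of the step or show that it would hold on a further core.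

The compounds shown leave open whether a longer chain on the same oxygen, such as butanoyl in place of acetyl, would give a similar step. They also leave open what an amine in place of the hydroxy group would do.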